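Swapping Phenyl for Cyclopropyl on a Shared Core

The source may hold more compounds than are shown below. What is called first, only, known or untested is meant among the compounds shown, and "the series" means these compounds.

In a functional assay on HepG2 cells (Homo sapiens) for antiproliferative activity, read by MTT assay, with a stated time of 72 h (on this read-out lower numbers stand for stronger inhibition and higher numbers for weaker inhibition), compound 1 `COc1ncc(-c2ccc3c(c2)N(c2ccccc2)C(=O)CO3)cc1NS(=O)(=O)c1ccc(F)cc1` gives 14000 nM.
Compound 2 `COc1ncc(-c2ccc3c(c2)N(C2CC2)C(=O)CO3)cc1NS(=O)(=O)c1ccc(F)cc1` gives 14400 nM in this assay.
Compound 3 `O=C1COc2ccc(-c3cnc(Cl)c(NS(=O)(=O)c4ccc(F)cc4)c3)cc2N1c1ccccc1` gives 35700 nM in this assay.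

The three share one core, and the core of compound 3 differs from that of compound 1 by chloro in place of methoxy on an aromatic carbon, a change that made the step of a 2.6-fold higher number from compound 1 to compound 3 (0.41 log units; beyond the scatter). The change from compound 1 to compound 2, (cyclopropyl in place of phenyl on an amide-type nitrogen in a ring), made the step of a 1.0-fold higher number from compound 1 to compound 2 (0.01 log units; within the scatter). Compound 4 `O=C1COc2ccc(-c3cnc(Cl)c(NS(=O)(=O)c4ccc(F)cc4)c3)cc2N1C1CC1` is not yet measured; it arises from compound 3 by the same change, (cyclopropyl in place of phenyl on an amide-type nitrogen in a ring), at a place described in the same words. Because the step of a 1.0-fold higher number from compound 1 to compound 2 (0.01 log units; within the scatter) stayed within the scatter, the step from compound 3 to compound 4 in this assay is expected to be about as small, a 1.0-fold higher number from compound 3 to compound 4 (0.00 log units; within the scatter). Compound 4 is therefore estimated at 36000 nM, with a likely range from 18000 nM to 72000 nM.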

Compound 4, half-maximal inhibitory concentration: 8510 nM
The estimate for compound 4 lay 4.2-fold (0.63 log units) above the measured number; the measured number lies below the stated range.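

In this assay, cyclopropyl in place of phenyl on the amide-type nitrogen in a ring did not behave the same way on both cores, giving a 4.2-fold lower number from compound 3 to compound 4 (0.62 log units; beyond the scatter) where chloro replaces methoxy, so the two steps disagree: the same change on two cores in this assay, a 1.0-fold higher number (0.01 log units; within the scatter) from compound 1 to compound 2 and a 4.2-fold lower number (0.62 log units; beyond the scatter) from compound 3 to compound 4, 4.3-fold (0.63 log units) apart, beyond the scatter of two such steps. Chloro in place of methoxy, read on the cyclopropyl compounds, gave a 1.7-fold lower number from compound 2 to compound 4 (0.23 log units; within the scatter), and this also disagrees with its earlier step: the same change on two cores in this assay, a 2.6-fold higher number (0.41 log units; beyond the scatter) from compound 1 to compound 3 and a 1.7-fold lower number (0.23 log units; within the scatter) from compound 2 to compound 4, 4.3-fold (0.63 log units) apart, beyond the scatter of two such steps. In these four compounds, then, the result of each change depends on the group present at the other place, but this does not show why, nor that the same holds beyond them.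

Open, from the compounds shown here alone, is what a methyl group or a longer chain on that nitrogen would do. Also open, going by these compounds, is whether an amine in place of the chloro or methoxy would change the picture.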